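The source may report more compounds than this note shows. Statements on the series, on what has been measured and on what is new or still open speak of the compounds shown alone.

The measured compounds:

Compound 1 `Cc1ccc(NC(=O)Nc2cccc(CNc3nccnc3Cl)c2)cc1C` gives 10700 nM in a functional assay on HepG2 cells (Homo sapiens) for antiproliferative activity, read by MTT assay, with a stated time of 48 h; a higher number here means a weaker inhibitor, a lower number a stronger inhibitor.
Compound 2 `O=C(Nc1cccc(CNc2nccnc2Cl)c1)NC1CCCCC1` reaches only a limit of the assay, > 40000 nM, in this assay, and this is a limit rather than a number.
Compound 3 `O=C(Nc1ccc(Cl)cc1)Nc1cccc(CNc2nccnc2Cl)c1` gives 8350 nM in this assay.

Compound 1 and compound 3 cannot be told apart on these numbers, since a 1.3-fold lower number from compound 1 to compound 3 (0.11 log units; within the scatter) stays within the scatter; compound 2 sits at a limit of > 40000 nM in this assay, at which 1 of the 3 values shown sits, and gives no number to compare. Compound 4 `Cc1ccccc1NC(=O)Nc1cccc(CNc2nccnc2Cl)c1` is the next compound to consider. It differs from compound 1 in one place: 2-methylphenyl in place of 3,4-dimethylphenyl on an amide-type nitrogen.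

Two earlier steps speak to this change. Swapping one aromatic group for another gave a 1.3-fold lower number from compound 1 to compound 3 (0.11 log units; within the scatter), a step within the scatter. Swapping the aromatic group for a saturated cyclohexyl gave an at least 3.7-fold higher number from compound 1 to compound 2 (0.57 log units; beyond the scatter), a step beyond the scatter, and the return swap gave an at least 4.7-fold lower number from compound 2 to compound 3 (0.68 log units; beyond the scatter). The change to compound 4 keeps an aromatic group on the amide-type nitrogen, so no step beyond the scatter is expected in this assay, and the step is estimated as a 1.1-fold higher number from compound 1 to compound 4 (0.05 log units; within the scatter). Compound 4 is therefore expected to give about 12000 nM, with a likely range from 6000 nM to 30000 nM.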

Compound 4, half-maximal inhibitory concentration: 15300 nM
Beside the measured number, compound 4's estimate is 1.3-fold (0.11 log units) below it; the range from low to high includes it.
By their numbers in this assay, from the lowest: compounds 3, 1 and 4 (each within the scatter of the next). At a limit, above all of these: compound 2.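

In this assay, a third aromatic group behaves like the first two: the change to 2-methylphenyl gives a 1.4-fold higher number from compound 1 to compound 4 (0.16 log units; within the scatter), and the same group in place of 4-chlorophenyl gives a 1.8-fold higher number from compound 3 to compound 4 (0.26 log units; within the scatter), so compounds 1, 3 and 4 are not separated even though their rings carry different groups in different places. The contrast with the saturated ring also holds for this new aromatic group, with an at least 2.6-fold lower number from compound 2 to compound 4 (0.41 log units; beyond the scatter), so all three aromatic compounds now stand apart from compound 2. Compound 2 itself gives a limit and not a number: the limit of > 40000 nM in this assay, at which 1 of the 4 values shown sits.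

The compounds shown leave open what an unsubstituted phenyl or a pyridine ring would do at this position. They also leave open whether a phenyl ring carrying an amine or a carboxylic acid would move the number beyond the scatter.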